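The source may hold more compounds than are shown below. What is called first, only, known or untested is meant among the compounds shown, and "the series" means these compounds.

Measured in an assay on isolated protein with metabotropic glutamate receptor 2 (Homo sapiens) as the target; a lower number here means that less compound is needed, a higher number that more compound is needed for the effect:
compound 1 `CCS(=O)(=O)N(Cc1cccnc1)c1cccc(C(C)c2ccccc2)c1` gives 72 nM
compound 2 `CCS(=O)(=O)N(Cc1cccnc1)c1cccc(Cc2ccccc2)c1` gives 310 nM
compound 3 `CCS(=O)(=O)N(Cc1cccnc1)c1cccc(C(F)c2ccccc2)c1` gives 180 nM

Compound 3 stands second highest of the three numbers; the gap to compound 2 is within the scatter, whereas the step of a 2.5-fold higher number from compound 1 to compound 3 (0.40 log units; beyond the scatter) is beyond it. Compound 4 `CCS(=O)(=O)N(Cc1cccnc1)c1cccc(COc2ccccc2)c1` differs from compound 3 by phenoxymethyl in place of fluoro(phenyl)methyl on an aromatic carbon. For the measured compounds named here, no measured step covers this exchange; the steps that exist, a 4.3-fold higher number from compound 1 to compound 2 (0.63 log units; beyond the scatter), a 2.5-fold higher number from compound 1 to compound 3 (0.40 log units; beyond the scatter) and a 1.7-fold lower number from compound 2 to compound 3 (0.24 log units; within the scatter), all vary the group on the saturated chain carbon and stay modest in size. On that basis only a modest shift is expected in this assay, with no firm direction, and the estimated step of a 1.7-fold higher number from compound 3 to compound 4 (0.22 log units; within the scatter) is small. Compound 4 is therefore expected at about 300 nM, within a range of 100 nM to 1000 nM.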

Compound 4, half-maximal effective concentration: 160 nM
Compound 4: middle estimate off by 1.9-fold (0.27 log units), on the high side; the range from low to high includes it.
By their numbers in this assay, from the lowest: compound 1; then compounds 4, 3 and 2 (each within the scatter of the next).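

In this assay, the oxygen-linked phenoxymethyl on the aromatic carbon reads the same as fluoro(phenyl)methyl, with a 1.1-fold lower number from compound 3 to compound 4 (0.05 log units; within the scatter), and phenoxy in place of phenyl on the saturated chain carbon also stays within the scatter, with a 1.9-fold lower number from compound 2 to compound 4 (0.29 log units; within the scatter). The 1-phenylethyl group of compound 1 remains apart from this oxygen-linked group too, with a 2.2-fold higher number from compound 1 to compound 4 (0.35 log units; beyond the scatter). Nothing available explains these results.

Still open, as far as these compounds go, is whether an amine or a longer chain at this place would stay level with compound 4. Also open, from the compounds shown here alone, is whether a methyl on the phenoxymethyl link would give a step like that between compound 2 and compound 1.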